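This account rests on a few compounds, and the source may have more. Where it says the series, first, only, none or still open, it means among the compounds named here.

Two close relatives of a shared core open this series. Compound 1, `Cc1ccc(C(=O)c2sc(Nc3ccccc3)c(C(=O)O)c2C)cc1`, carries an unsubstituted phenylamino group and in a functional assay, with a stated time of 150 min, tested at 35 ug/mL (a higher number here means a stronger effect of the compound at the concentration tested, a lower number a weaker effect), compound 1 gives 5.55%, a small response at the concentration tested. Compound 2, `Cc1ccc(Nc2sc(C(=O)c3ccc(C)cc3)c(C)c2C(=O)O)cc1`, carries a (4-methylphenyl)amino group instead, and in this assay compound 2 is reported as "not active" (no number reported) with no number attached. Compound 2 therefore stands without a figure of its own: all that is known is that the assay did not register an effect worth reporting, which places it no higher than compound 1, and the two may well lie within the usual scatter of each other.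

Compound 3, `Cc1ccc(C(=O)c2sc(Nc3ccc(Cl)cc3)c(C(=O)O)c2C)cc1`, is the next variation. It differs from compound 2 by chloro in place of methyl on an aromatic carbon. Both measured compounds sit at the low end of the scale, so the change from compound 2 to compound 3 is expected to produce no step beyond the scatter in this assay in either direction. Compound 3 is accordingly estimated to give about 6%, within a range from 0% to 18%.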

Compound 3, a percentage reported as activity, at one concentration (the size of the read-out at that concentration, not a potency): "not active" (no number reported)
Compound 3 has no reported number here, so the estimate cannot be set against anything.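

Compound 2 and compound 3 both lack a reported number in this assay, so no step can be read for chloro in place of methyl. The compounds shown leave open whether this change alters the effect at all, since neither compound has a figure to compare. No measured evidence bears on this result.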